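From 2-chlorophenyl to 3-hydroxyphenyl: notes on compound 3

The source may hold more compounds than are shown below. What is called first, only, known or untested is meant among the compounds shown, and "the series" means these compounds.

In a functional assay on HepG2 cells (Homo sapiens) for antiproliferative activity, read by MTT assay, with a stated time of 24 h (a lower number here means a stronger inhibitor, a higher number a weaker inhibitor), compound 1 (`COc1ccc(C(=O)/C=C/c2ccco2)c2c1C=CC(C)(C)O2`) gives > 10000 nM as a limit of the assay. Compound 2 (`COc1ccc(C(=O)/C=C/c2ccccc2Cl)c2c1C=CC(C)(C)O2`) stands at > 10000 nM as a limit too. Within the data shown here, the one measured step is a step that the two limits leave unreadable from compound 1 to compound 2 and it carries no size forward. Compound 3 (`COc1ccc(C(=O)/C=C/c2cccc(O)c2)c2c1C=CC(C)(C)O2`) has 3-hydroxyphenyl in place of 2-chlorophenyl (3-hydroxyphenyl in place of 2-chlorophenyl on a double-bonded chain carbon bound to a double-bonded chain carbon) on a double-bonded chain carbon bound to a double-bonded chain carbon. Among the measured compounds shown here, no measured size applies to this change because of the limit of > 10000 nM in this assay, at which 2 of the 2 values shown sit, and that is the only guide. The step expected is a number no higher from compound 2 to compound 3 (the limit leaves the size open) with activity staying close to that limit in this assay and no firm direction. Compound 3 is estimated at 10000 nM with 3000 nM to 30000 nM as its expected range.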

Compound 3, half-maximal inhibitory concentration: > 10000 nM
Compound 3 gave a limit, no number; the forecaster's own chance of this, stated with the estimate: 60%; the middle value lies on the limit itself.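

Compound 1, compound 2 and compound 3 all give limits, not numbers, so no step among them can be read: the limit of > 10000 nM in this assay, at which 3 of the 3 values shown sit.

The compounds shown leave open whether any group in this place, on a double-bonded chain carbon bound to a double-bonded chain carbon, gives a readable number.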